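A few compounds are considered here, and "the series" means these few. Any claim that something is new, unique, unknown or untested is made for them only; others in the source may bear on it.

Measured compounds:
- compound 1 `COc1c(F)c(F)c(F)c(F)c1C(=O)O`: 53.8%
- compound 2 `O=C(O)c1c(O)c(F)c(F)c(F)c1F`: no result reported
- compound 3 `O=C(O)c1ccc(F)c(F)c1O`: no result reported

In a functional assay on the whole organism for inhibition, with Rattus norvegicus as the target, read by paw edema, with stated times of 30 min and 3 h, at a dose of 25 mg/kg by the intraperitoneal route (on this read-out higher numbers stand for more inhibition at the one dose given (going by the name of the read-out) and lower numbers for less inhibition), only compound 1 has a number: compound 1 gives 53.8%. Compound 2 gives no result reported, and compound 3 gives no result reported, so nothing can be said about how they compare with compound 1 or with each other. Among the compounds with values here, compound 2 therefore stands without any place on the scale; there is only one measured value in the whole set, and no step between two measured compounds.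

Compound 4 `O=C(O)c1c(O)c(F)cc(F)c1F` differs from compound 2 in one place: hydrogen in place of fluoro on an aromatic carbon. Within the data shown here, since compound 2 itself has no value, no step can be built for this change, and the only anchor is compound 1, a relative with a different substituent pattern. The expectation for the step in this assay is therefore no clear direction and no size beyond the scatter, with wide uncertainty. Compound 4 is expected to give about 45%, estimated to lie between 15% and 70%.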

Compound 4, a percentage reported as inhibition, in the whole organism at one dose (the size of the read-out at that dose, not a potency): 47%
For compound 4 the middle estimate is 2 percentage points below the measured one; measured number inside the range.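

No step can be read between compound 2 and compound 4: in this assay compound 4 gives 47%, while compound 2 has no number to set against it. Whether replacing that fluoro with hydrogen changes inhibition stays open with the compounds shown. Nothing available here bears on this result.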